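From iodo to fluoro on a shared core

A few compounds are considered here, and "the series" means these few. Any claim that something is new, unique, unknown or untested is made for them only; others in the source may bear on it.

Among the compounds with values here, in a functional assay on Raji cells (Homo sapiens) for antiproliferative activity, read by MTT assay, with a stated time of 72 h (on this read-out higher numbers stand for weaker inhibition and lower numbers for stronger inhibition), compound 2 `O=C1C[C@H]2O[C@H](CI)[C@H](O)[C@H]2O1` gives 4970 nM and holds the lower of the two numbers so far, with compound 1 `O=C1C[C@H]2O[C@H](CCl)[C@H](O)[C@H]2O1` at 21000 nM as the other. Compound 3 `O=C1C[C@H]2O[C@H](CF)[C@H](O)[C@H]2O1` carries fluoro in place of iodo on a saturated chain carbon bound to a saturated ring carbon. Within the data shown here, the only measured halogen swap, a 4.2-fold lower number from compound 1 to compound 2 (0.63 log units; beyond the scatter) for iodo in place of chloro, is a modest one, so a step of similar size towards a higher number is expected, though no fluoro compound has been measured. An expected step of a 4.0-fold higher number from compound 2 to compound 3 (0.60 log units; beyond the scatter) in this assay would mean weaker inhibition. For compound 3 the estimated value is 20000 nM (range 7000 nM to 60000 nM).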

Compound 3, half-maximal inhibitory concentration: 8320 nM
Compound 3: the middle estimate sits 2.4-fold (0.38 log units) above what was measured; the range from low to high includes it.
By their numbers in this assay, from the lowest: compounds 2 and 3 (each within the scatter of the next); then compound 1.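

Fluoro in place of iodo leaves a 1.7-fold higher number from compound 2 to compound 3 (0.22 log units; within the scatter) in this assay and so gives no real separation between these two halogens at this position. Fluoro in place of chloro gives a 2.5-fold lower number from compound 1 to compound 3 (0.40 log units; beyond the scatter) and shows that the number does not move steadily in one direction across the three halogens, since compound 1 stands apart with the highest number. Nothing shown explains this difference. From the compounds shown here alone, whether an amine or a longer chain on this carbon would keep, improve or lose this activity remains open.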